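Aryloxyacetamide series: five-membered to six-membered ring swap

The compounds below may be only part of what the source reports. "The series", "measured", "known", "first", "only" and "open" are said of these compounds alone.

Measured so far:
- compound 1 `Cc1ccc(OCC(=O)N(Cc2cccs2)c2cnn(C)c2)cc1`: 63000 nM
- compound 2 `CCN(Cc1cccn1C)C(=O)COc1ccc(C)cc1`: 21300 nM
- compound 3 `C=CCN(Cc1cccs1)C(=O)COc1ccc(C)cc1`: 20 nM

In an assay on HEK293 cells for agonist activity at transient receptor potential cation channel subfamily M member 8 (Homo sapiens), read by fluorescence and calcium flux, with a stated time of 15 min (on this read-out lower numbers stand for an effect already at smaller amounts and higher numbers for an effect only at larger amounts of compound), compound 2 gives 21300 nM, the second highest of the three numbers. Compound 1 sits nearest, with a higher number, and compound 3 lies far below both; compound 3 differs from compound 2 in two places at once, so its value only shows where the series can reach.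

Among the compounds with values here, the one single-point step recorded is a 3200-fold lower number from compound 1 to compound 3 (3.50 log units; beyond the scatter), a change on the amide-type nitrogen. Compound 4 `CCN(Cc1ccccn1)C(=O)COc1ccc(C)cc1` changes a different place: pyridin-2-yl in place of 1-methyl-1H-pyrrol-2-yl on a saturated chain carbon bound to an amide-type nitrogen. Within the data shown here, no measured pair isolates this swap, and the step from compound 1 to compound 3 does not bear on it. Within the shared core of compound 2, with the ethyl group kept, the expectation is therefore anchored on the value of compound 2 alone, with a wide range in both directions.

Compound 4 is expected to give 15000 nM (range 2000 nM to 100000 nM) in this assay, which is estimated as a 1.4-fold lower number from compound 2 to compound 4 (0.15 log units; within the scatter), with no direction supported beyond the scatter.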

Compound 4, half-maximal effective concentration: 16000 nM
Beside the measured number, compound 4's estimate is 1.1-fold (0.03 log units) below it, and the stated range covers the measured number.
By their numbers in this assay, from the lowest: compound 3; then compounds 4 and 2 (each within the scatter of the next); then compound 1.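

In this assay, within the data shown here, the replacement of 1-methyl-1H-pyrrol-2-yl by pyridin-2-yl on a saturated chain carbon bound to an amide-type nitrogen reads as a 1.3-fold lower number from compound 2 to compound 4 (0.12 log units; within the scatter) and is the first single-place step at this position. With the ethyl group kept, going from one five-membered aromatic ring to one six-membered aromatic ring, at equal counts of heavy atoms, donors and acceptors, therefore gives no difference beyond the scatter for this pair. Nothing on hand offers an explanation for this result.

Open, from the compounds shown here alone, is whether the same holds with allyl in place of ethyl on the amide-type nitrogen. Also open, going by these compounds, is whether phenyl or a carboxylic acid at this place would give a step beyond the scatter.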